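Swapping 4-chlorophenyl for 2,6-dibromophenyl on the shared core

A few compounds are considered here, and "the series" means these few. Any claim that something is new, unique, unknown or untested is made for them only; others in the source may bear on it.

In a physicochemical assay for solubility, in phosphate buffer, measured as kinetic solubility, at pH 7.4 (a higher number here means a more soluble compound, a lower number a less soluble compound), compound 1 (`Cc1ccccc1-c1nc(CN2CCC(C(=O)NCCCN3CCC(C(C)C)CC3)CC2)c(C)o1`) gives > 71 ug/mL as a limit of the assay and not a number. Compound 2 (`Cc1ccccc1-c1nc(CN2CCC(C(=O)NCCCN3CCC(C)(C)CC3)CC2)c(C)o1`) gives > 69 ug/mL as a limit too. Compound 3 (`Cc1oc(-c2ccc(Cl)cc2)nc1CN1CCC(C(=O)NCCCN2C[C@H](C)C[C@H](C)C2)CC1`), the starting point of this step, also stands only at a limit, > 72 ug/mL in this assay.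

Compound 4 (`Cc1oc(-c2c(Br)cccc2Br)nc1CN1CCC(C(=O)NCCCN2C[C@H](C)C[C@H](C)C2)CC1`) has not yet been measured. It carries 2,6-dibromophenyl in place of 4-chlorophenyl on an aromatic carbon, a change counted as 2,6-dibromophenyl in place of 4-chlorophenyl on an aromatic carbon on the otherwise shared core.

Going by the values given here, only one measured step exists, a step that the two limits leave unreadable from compound 1 to compound 2 as its reading, and it concerns a different group, so it offers no size for this change. With nothing but limits to go on, no shift beyond the usual scatter is expected in this assay, and the expected step is a step that the limit leaves unreadable from compound 3 to compound 4 for now. Compound 4 is estimated at 75 ug/mL with an expected range from 35 ug/mL to 95 ug/mL in this assay, and the reading may well prove to be another limit.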

Compound 4, solubility: 62.4 ug/mL
Estimate against measurement, compound 4: 1.2-fold (0.08 log units) above, and the stated range covers the measured number.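

In this assay, compound 4 gives the first reading among the compounds shown that is a number and not a limit of the assay, 62.4 ug/mL. Putting 2,6-dibromophenyl in place of 4-chlorophenyl on this aromatic carbon gives an at least 1.1-fold lower number from compound 3 to compound 4 (0.06 log units; that floor lies within the scatter), and that figure is only a floor for the step. The true size of the step stays unknown because compound 3 is known only as a limit: the limit of > 72 ug/mL in this assay, at which 1 of the 4 values shown sits.

The earlier step between the two compounds that differ in their piperidine group cannot be read, so the compounds shown offer no second step to set beside this one. They also leave open how this position would read in this assay with a phenyl bearing an amine or a carboxylic acid in place of the halogens.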